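Acetyl in Place of Methyl: Expecting a Fourth Value

The source may report more compounds than this note shows. Statements on the series, on what has been measured and on what is new or still open speak of the compounds shown alone.

Three compounds have so far been measured in a functional assay on the whole organism (stomach) for inhibition, with Canis familiaris (Canis lupus familiaris) as the target, at a dose of 5 mg/kg by the intravenous route; a higher number here means a stronger effect of the compound at the dose given, a lower number a weaker effect:

compound 1 `Cc1nc2c(OCc3ccccc3)cccn2c1CCC#N` gives 20%
compound 2 `COCc1c(C)nc2c(OCc3ccccc3)cccn12` gives 29%
compound 3 `Cc1nc2c(OCc3ccccc3)cccn2c1Cl` gives 37%

Compound 2 stands second highest of these three numbers. Its steps to both neighbours, a number 9 percentage points higher from compound 1 to compound 2 (within the scatter) and a number 8 percentage points higher from compound 2 to compound 3 (within the scatter), lie within the usual scatter, so nothing separates it clearly from either. Only the longer step of a number 17 percentage points higher from compound 1 to compound 3 (beyond the scatter) reaches beyond the scatter, and that one is modest.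

The unmeasured compound 4 `CC(=O)OCc1c(C)nc2c(OCc3ccccc3)cccn12` differs from compound 2 by acetyl in place of methyl on an oxygen on a saturated carbon. Among the compounds with values here, two measured steps touch the same part of the molecule: the exchange at the saturated chain carbon in a number 9 percentage points higher from compound 1 to compound 2 (within the scatter) and the removal of the methoxymethyl group in a number 8 percentage points higher from compound 2 to compound 3 (within the scatter). Within the data shown here, both stayed within the scatter, and none of the measured steps involves an acetyl group at all. The data therefore give no reason to expect a step beyond the scatter in this assay in either direction.

Compound 4 is thus expected to give about 30%, with a range from 15% to 45%. The step this estimate implies is a number 1 percentage points higher from compound 2 to compound 4 (within the scatter), expected to stay within the scatter.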

Compound 4, a percentage reported as inhibition, in the whole organism at one dose (the size of the read-out at that dose, not a potency): 87%
The estimate for compound 4 lay 57 percentage points below the measured number; the measured number lies above the stated range.
By their numbers in this assay, from the lowest: compounds 1, 2 and 3 (each within the scatter of the next, the first and the last beyond it); then compound 4.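

Acetyl in place of methyl on this oxygen is a large change in this assay, a number 58 percentage points higher from compound 2 to compound 4 (beyond the scatter), and none of the earlier steps came near that size, so this side chain is far from indifferent to what sits on its oxygen. Compound 4 also stands clear of the other two compounds, with a number 50 percentage points higher from compound 3 to compound 4 (beyond the scatter) and a number 67 percentage points higher from compound 1 to compound 4 (beyond the scatter), which makes acetoxymethyl the group with the strongest effect at this dose among the four compounds. The data shown offer no explanation for the jump.

On these data alone, whether the gain belongs to acetyl alone or extends to a longer acyl chain such as propionyl, or to a benzoyl group, stays open. A hydroxymethyl group at the same place, or an acetamidomethyl group with nitrogen in place of the oxygen, would also show how much of the effect depends on the ester itself.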